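The source may hold more compounds than are shown below. What is called first, only, known or untested is meant among the compounds shown, and "the series" means these compounds.

Measured so far in a functional assay on NCI-H460 cells (Homo sapiens) for cytotoxicity, read by MTT assay; on this read-out higher numbers stand for weaker inhibition and lower numbers for stronger inhibition:
compound 1 `CCc1cc(S(=O)(=O)N2C[C@H](c3ccccc3)NC2=O)ccc1NC(=O)c1ccc([N+](=O)[O-])cc1` gives 800 nM
compound 2 `CCc1cc(S(=O)(=O)N2C[C@H](c3ccccc3)NC2=O)ccc1NC(=O)NC1CCCCC1` gives 300 nM

Compound 2 has the lower of the two numbers in this assay; its nearest neighbour is compound 1, and the step of a 2.7-fold lower number from compound 1 to compound 2 (0.43 log units; beyond the scatter) lies beyond the scatter. That step is the only one measured, and it replaces the carbonyl-borne 4-nitrophenyl of compound 1 with cyclohexylamino.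

Compound 3 `CCc1cc(S(=O)(=O)N2C[C@H](c3ccccc3)NC2=O)ccc1NC(=O)c1ccc(N)cc1` differs from compound 2 by 4-aminophenyl in place of cyclohexylamino on a carbonyl carbon. This change runs in part against the measured step: the cyclohexylamino that gave compound 2 its lower number leaves again, and an aryl group returns on the carbonyl carbon, though with an amino group in place of the nitro group of compound 1. Going by the values given here, no measured pair shows the 4-nitrophenyl to 4-aminophenyl exchange, so that part is uncharted.

Compound 3 is therefore expected to move back toward compound 1, with a step of a 2.0-fold higher number from compound 2 to compound 3 (0.30 log units; within the scatter) in this assay, because a 2.7-fold lower number from compound 1 to compound 2 (0.43 log units; beyond the scatter) was modest and only part of it is reversed here. The estimate for compound 3 is 600 nM, within 250 nM to 1500 nM.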

Compound 3, half-maximal inhibitory concentration: 670 nM
Compound 3: the middle estimate sits 1.1-fold (0.05 log units) below what was measured; measured number inside the range.
By their numbers in this assay, from the lowest: compound 2; then compounds 3 and 1 (each within the scatter of the next).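

In this assay, amino in place of nitro on the aromatic carbon gives a 1.2-fold lower number from compound 1 to compound 3 (0.08 log units; within the scatter), so the 4-nitrophenyl and 4-aminophenyl compounds cannot be told apart, and this exchange has no readable effect here. Replacing cyclohexylamino with 4-aminophenyl on the carbonyl carbon gives a 2.2-fold higher number from compound 2 to compound 3 (0.35 log units; beyond the scatter), which sets compound 2 apart from compound 3 as well as from compound 1, although this step is modest and the entering and leaving groups have the same heavy-atom count and each hold one six-membered ring. The step changes the ring from non-aromatic to aromatic and removes the nitrogen from the carbonyl carbon together, so the two changes cannot be separated, and no measurement on hand accounts for the difference.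

Still open, on these data alone, is whether phenylamino or cyclohexyl on the carbonyl carbon would read with compound 2 or with compound 3, a pair that would separate the ring from the nitrogen. Also open, as far as these compounds go, is whether the match between compound 1 and compound 3 extends to other groups on the phenyl ring, such as 4-methoxyphenyl or 4-carboxyphenyl.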